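Reversing a sulfonyl for a sulfanyl on the shared core

The source may hold more compounds than are shown below. What is called first, only, known or untested is meant among the compounds shown, and "the series" means these compounds.

Compound 1 `COc1cc(OC)c(/C=C(/SCc2ccc(Cl)c(Cl)c2)C(=O)c2ccc(Cl)cc2)c(OC)c1`: 10000 nM
Compound 2 `O=C(/C(=C\c1ccccc1OCc1ccccc1)SCc1ccc(F)cc1)c1ccc(Cl)cc1`: 1000 nM
Compound 3 `COc1cc(OC)c(/C=C(\C(=O)c2ccc(Cl)cc2)S(=O)(=O)Cc2ccc(F)cc2)c(OC)c1`: 25000 nM

In a functional assay on DU-145 cells (Homo sapiens) for inhibition, read by trypan blue exclusion, with a stated time of 96 h (on this read-out lower numbers stand for stronger inhibition of growth and higher numbers for weaker inhibition of growth), compound 3 gives the highest of the three numbers; its nearest neighbour is compound 1, and compound 2 lies furthest from it. Compound 4 `COc1cc(OC)c(/C=C(/Sc2ccc(C)cc2)C(=O)c2ccc(Cl)cc2)c(OC)c1` differs from compound 3 in one place: (4-methylphenyl)sulfanyl in place of (4-fluorobenzyl)sulfonyl on a double-bonded chain carbon bound to a carbonyl carbon and a double-bonded chain carbon. Within the data shown here, the only measured step at the same place is a 2.5-fold higher number from compound 1 to compound 3 (0.40 log units; beyond the scatter), which moved the number upward when a sulfanyl group was replaced by a sulfonyl group. Among the measured compounds shown here, compound 4 goes the other way, returning to a sulfanyl group, though an aryl rather than a benzyl one, for which no measured pair gives guidance. The step is therefore expected to run downward, of roughly the size seen between compound 1 and compound 3, so that compound 4 is estimated at a 2.5-fold lower number from compound 3 to compound 4 (0.40 log units; beyond the scatter). In this assay compound 4 is expected to give about 10000 nM, within a range from 3000 nM to 30000 nM.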

Compound 4, concentration for 50% growth inhibition: > 100000 nM
Compound 4 gave a limit, no number; the forecaster's own chance of this, stated with the estimate: 10%; middle value at least 10-fold (1.00 log units) away from the limit.
By their numbers in this assay, from the lowest: compound 2; then compound 1; then compound 3. At a limit, above all of these: compound 4.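

In this assay compound 4 gives no number, only a limit: the limit of > 100000 nM in this assay, at which 1 of the 4 values shown sits. Going back to a sulfanyl group at this position therefore did not lower the number, as the change gave an at least 4.0-fold higher number from compound 3 to compound 4 (0.60 log units; beyond the scatter), so a sulfanyl group alone does not bring back the level of compound 1. With sulfanyl kept on both sides, 4-methylphenyl in place of 3,4-dichlorobenzyl on a sulfur gave an at least 10-fold higher number from compound 1 to compound 4 (1.00 log units; beyond the scatter), which shows that the group carried on the sulfur matters in its own right, something the earlier step could not separate from the change to sulfonyl.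

The compounds shown leave open how the sulfanyl and sulfonyl forms compare when the group on the sulfur stays the same. They also leave open whether a longer chain on the sulfur, or an amine in place of the methyl group, would move the number.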